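Swapping the Aryl Amide for a Small Ring Amide

The source may report more compounds than this note shows. Statements on the series, on what has been measured and on what is new or still open speak of the compounds shown alone.

compound 1 `Cc1cccc(Cn2c(CN3CCN(C(=O)c4ccc(C(C)C)cc4)CC3)nc3ccccc32)c1`: 67.6%
compound 2 `O=C(C1CC1)N1CCN(Cc2nc3ccccc3n2Cc2ccc(F)cc2)CC1`: 32.7%

Of the compounds shown here, two of the shared core have been measured in an assay on isolated protein for inhibition of aldehyde dehydrogenase 1A1 (Homo sapiens), read by spectrophotometry, tested at 10 uM; a lower number here means less inhibition, a higher number more inhibition at the concentration tested (going by the name of the read-out). Compound 1 gives 67.6%, the higher of the two numbers. Compound 2 gives 32.7%, a number well below that of compound 1, beyond the scatter. Going by the values given here, no step between compounds that differ in one place is available, so nothing ties a single change to a single shift.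

Compound 3 `Cc1cccc(Cn2c(CN3CCN(C(=O)C4CCC4)CC3)nc3ccccc32)c1` has not been measured. It differs from compound 1 in one place: cyclobutyl in place of 4-isopropylphenyl on a carbonyl carbon. The carbonyl carbon that carried the 4-isopropylphenyl group now carries a cyclobutyl group, the amide-type nitrogen in a ring being unchanged.

Among the compounds with values here, with no measured step of this kind, the expectation rests on the two values alone. Compound 1 sits high with 67.6%; compound 2, whose number is 32.7%, shows that a much lower figure is reached within this set. Compound 3 is expected to come in lower, a number 27.6 percentage points lower from compound 1 to compound 3 (beyond the scatter), a step beyond the scatter. Compound 3 is estimated at 40%, between 20% and 60%.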

Compound 3, a percentage reported as inhibition, at one concentration (the size of the read-out at that concentration, not a potency): 69.1%
For compound 3 the middle estimate is 29.1 percentage points below the measured one; measured number outside the range, above it.
By their numbers in this assay, from the lowest: compound 2; then compounds 1 and 3 (each within the scatter of the next).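

Going by these compounds alone, the first step in the set that changes one place reads a number 1.5 percentage points higher from compound 1 to compound 3 (within the scatter) in this assay, with cyclobutyl in place of 4-isopropylphenyl on a carbonyl carbon. At this position, then, a six-membered aromatic ring of carbon bearing its isopropyl group can give way to a four-membered non-aromatic ring of carbon, with fewer heavy atoms, and the read-out stays within the scatter; for this pair, neither the aromatic ring nor the isopropyl group is needed to hold the inhibition seen at the concentration tested. No independent measurement bears on why the two compounds read alike.

From the compounds shown here alone, whether a straight butyl chain, a methyl group or a carboxylic acid on the same carbonyl carbon would hold the number remains open, and a read-out at one concentration gives no potency that could separate compound 1 from compound 3. Compound 3 differs from compound 2, with its 32.7%, in more than one place, so that lower number cannot be assigned to any single group.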